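4-Methoxyphenyl in place of cyclohexyl at the assay limit

The source may report more compounds than this note shows. Statements on the series, on what has been measured and on what is new or still open speak of the compounds shown alone.

In a functional assay on A-375 cells (Homo sapiens) for antiproliferative activity, read by MTT assay, with a stated time of 72 h (a higher number here means a weaker inhibitor, a lower number a stronger inhibitor), compound 1 (`COc1ncc(-c2ccc3c(c2)NC(=O)CO3)cc1NS(=O)(=O)c1ccc(F)cc1`) gives 26300 nM. Compound 2 (`COc1ncc(-c2ccc3c(c2)N(c2ccc(F)cc2)C(=O)CO3)cc1NS(=O)(=O)c1ccc(F)cc1`) gives > 40000 nM, which is a limit and not a number. Compound 3 (`COc1ncc(-c2ccc3c(c2)N(C2CCCCC2)C(=O)CO3)cc1NS(=O)(=O)c1ccc(F)cc1`) gives > 40000 nM, also a limit, so compound 3 has no measured number of its own. The data thus end at the limit of > 40000 nM in this assay, at which 2 of the 3 values shown sit.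

Compound 4 (`COc1ccc(N2C(=O)COc3ccc(-c4cnc(OC)c(NS(=O)(=O)c5ccc(F)cc5)c4)cc32)cc1`) carries 4-methoxyphenyl in place of cyclohexyl on an amide-type nitrogen in a ring.

Among the measured compounds shown here, three measured steps bear on this change. With 4-fluorophenyl on that nitrogen the record shows an at least 1.5-fold higher number from compound 1 to compound 2 (0.18 log units; that floor lies within the scatter). With cyclohexyl there it shows an at least 1.5-fold higher number from compound 1 to compound 3 (0.18 log units; that floor lies within the scatter). Both floors lie within the scatter, so neither step has a firm size. Between these two groups the record shows a step that the two limits leave unreadable from compound 2 to compound 3, and that step gives no size to carry over. Neither substituted compound gave a number, so no gain is expected from a further group at this place. The expected change, a number no higher from compound 3 to compound 4 (the limit leaves the size open), is none beyond the scatter, and a reading at the limit in this assay is the likeliest outcome. Compound 4 is estimated at 40000 nM, within an expected range of 20000 nM to 80000 nM.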

Compound 4, half-maximal inhibitory concentration: 18400 nM
Compound 4: middle estimate off by 2.2-fold (0.34 log units), on the high side, outside the stated range (below it).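

In this assay, setting 4-methoxyphenyl in place of hydrogen on the amide-type nitrogen gives a 1.4-fold lower number from compound 1 to compound 4 (0.16 log units; within the scatter), so a group on this nitrogen need not drive the reading to the limit, although 4-fluorophenyl and cyclohexyl both did so in compound 2 and compound 3. The choice of group therefore matters at this place: methoxy in place of fluoro on an aromatic carbon gives an at least 2.1-fold lower number from compound 2 to compound 4 (0.33 log units; beyond the scatter), and 4-methoxyphenyl in place of cyclohexyl gives an at least 2.1-fold lower number from compound 3 to compound 4 (0.33 log units; beyond the scatter). Both of these steps are floors and not full sizes, so the true gaps may be wider, and the readings of compound 2 and compound 3 set no upper end to them: the limit of > 40000 nM in this assay, at which 2 of the 4 values shown sit.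

Compound 4 still reads level with compound 1, so no group shown on this nitrogen gives a gain beyond the scatter over the unsubstituted core. From the compounds shown here alone, how an amine or a carboxylic acid in place of the methoxy would read remains open, as does the effect of a longer chain such as n-butyl on the nitrogen itself.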